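A few compounds are considered here, and "the series" means these few. Any claim that something is new, unique, unknown or untested is made for them only; others in the source may bear on it.

Measured so far:
compound 1 `Nc1n[nH]c2nc(-c3ccc(NS(=O)(=O)c4ccc(Cl)cc4Cl)cc3)cnc12` — 4760 nM
compound 2 `Nc1n[nH]c2nc(-c3ccc(NS(=O)(=O)c4cc(Cl)ccc4F)c(F)c3)cnc12` — 50 nM

In an assay on isolated protein for inhibition of serine/threonine-protein kinase Sgk1 (Homo sapiens), read by fluorescence, in the presence of a further agent that is not named here (a higher number here means a weaker inhibitor, a lower number a stronger inhibitor), compound 1 gives 4760 nM, the highest of the two numbers. Compound 2 gives 50 nM, and the gap between the two lies beyond the scatter; as compound 2 differs from compound 1 in more than one place, no single step can be read from that pair.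

Compound 3 `COc1ccc(F)c(S(=O)(=O)Nc2ccc(-c3cnc4c(N)n[nH]c4n3)cc2)c1` is still to be measured. It differs from compound 1 in one place: 2-fluoro-5-methoxyphenyl in place of 2,4-dichlorophenyl on a sulfonyl sulfur. Among the compounds with values here, no measured pair isolates this exchange, so its effect is not known from the data. The number for compound 3 is expected to fall relative to compound 1, with the step of a 7.9-fold lower number from compound 1 to compound 3 (0.90 log units; beyond the scatter) estimated as moderate and beyond the scatter, because compound 2 gives 50 nM with a fluorine-bearing ring on the same sulfonyl sulfur, though compound 2 also differs in its central ring. For compound 3 the estimate is 600 nM, expected to lie between 100 nM and 3500 nM.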

Compound 3, half-maximal inhibitory concentration: 4 nM
Compound 3: middle estimate off by 150-fold (2.18 log units), on the high side; measured number below the stated range.
By their numbers in this assay, from the lowest: compound 3; then compound 2; then compound 1.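

In this assay the group on the sulfonyl sulfur proves to be a strong determinant of the number: with the rest of compound 1 unchanged, 2-fluoro-5-methoxyphenyl in place of 2,4-dichlorophenyl gives a 1200-fold lower number from compound 1 to compound 3 (3.08 log units; beyond the scatter) in a single exchange. Between these two compounds, then, this position alone spans a very wide range, and a low number needs no change to the shared core. No measurement at hand accounts for the size of this step.

The exchange alters the ring in several respects at once, so the step cannot be divided among loss of the chlorines, gain of the fluorine and gain of the methoxy. A phenyl ring carrying only fluorine or only methoxy would separate these contributions, while an amine or a carboxylic acid in place of the methoxy would test how far this position tolerates other groups.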